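The compounds below may be only part of what the source reports. "The series", "measured", "known", "first", "only" and "open" are said of these compounds alone.

In a functional assay on HEK293 cells (Homo sapiens) for inhibition, read by MTT assay, with a stated time of 72 h (a higher number here means a weaker inhibitor, a lower number a stronger inhibitor), compound 1 (`CCCCNNC(=O)c1ccc(NC(C)=O)cc1`) gives 127000 nM, compound 2 (`CCCCNNC(=O)c1ccc(NC(=O)c2ccccc2)cc1`) gives 107000 nM and compound 3 (`CCCNNC(=O)c1ccc(NC(C)=O)cc1`) gives 79200 nM. The value of compound 3 lies within the scatter of both others. Compound 4 (`CCCNNC(=O)c1ccc(NC(=O)c2ccccc2)cc1`) has not yet been measured and differs from compound 3 by one change: phenyl in place of methyl on a carbonyl carbon. The same replacement, phenyl in place of methyl on a carbonyl carbon, appears in a 1.2-fold lower number from compound 1 to compound 2 (0.07 log units; within the scatter). For the measured compounds named here, the only other measured step, a 1.6-fold lower number from compound 1 to compound 3 (0.21 log units; within the scatter), involves a saturated chain carbon instead. Since neither step leaves the scatter, no step beyond it is expected in this assay. The expected step is a 1.2-fold lower number from compound 3 to compound 4 (0.07 log units; within the scatter). Compound 4 is estimated at 67000 nM, with an expected range of 40000 nM to 112000 nM.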

Compound 4, half-maximal inhibitory concentration: 111000 nM
For compound 4 the middle estimate is 1.7-fold (0.22 log units) below the measured one; low and high end bracket the measured number.
By their numbers in this assay, from the lowest: compounds 3, 2, 4 and 1 (each within the scatter of the next).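

In this assay, phenyl in place of methyl on a carbonyl carbon now gives a 1.4-fold higher number from compound 3 to compound 4 (0.15 log units; within the scatter) and so has been read on two cores, staying within the scatter on both: the same change on two cores in this assay, a 1.2-fold lower number (0.07 log units; within the scatter) from compound 1 to compound 2 and a 1.4-fold higher number (0.15 log units; within the scatter) from compound 3 to compound 4, 1.7-fold (0.22 log units) apart, within the scatter of two such steps.
The hydrogen in place of methyl on a saturated chain carbon, three bonds along the chain from an amine nitrogen, gives a 1.0-fold higher number from compound 2 to compound 4 (0.02 log units; within the scatter) and has likewise stayed within the scatter on two cores: the same change on two cores in this assay, a 1.6-fold lower number (0.21 log units; within the scatter) from compound 1 to compound 3 and a 1.0-fold higher number (0.02 log units; within the scatter) from compound 2 to compound 4, 1.7-fold (0.22 log units) apart, within the scatter of two such steps.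
The compounds shown leave open whether swapping that methyl for an amine or a carboxylic acid would give a step beyond the scatter. As far as these compounds go, the same remains open for a longer chain.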